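This account rests on a few compounds, and the source may have more. Where it says the series, first, only, none or still open, it means among the compounds named here.

Measured compounds:
- compound 1 `CCc1ccccc1N(Cc1nnc(Cc2ccccc2)o1)S(=O)(=O)c1ccc(C)cc1` — 398 nM
- compound 2 `CCc1ccccc1N(Cc1nnc(Cc2ccc(OC)cc2)o1)S(=O)(=O)c1ccc(C)cc1` — 631 nM
- compound 3 `Cc1ccc(S(=O)(=O)N(Cc2nnc(Cc3ccccc3F)o2)c2cccc(Cl)c2C)cc1` — 631 nM

All three numbers come from a functional assay on CHO cells for antagonist activity at prostaglandin E2 receptor EP1 subtype (Homo sapiens), read by FLIPR and calcium flux; a higher number here means a weaker inhibitor, a lower number a stronger inhibitor. Compound 3 stands level with compound 2 at the digits read, and its number differs from that of compound 1 only within the scatter, so the three sit in one narrow band. Among the compounds with values here, the only single-point step among them, a 1.6-fold higher number from compound 1 to compound 2 (0.20 log units; within the scatter), is itself within the scatter.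

Compound 4 `COc1ccc(Nc2nnc(CN(c3cccc(Cl)c3C)S(=O)(=O)c3ccc(C)cc3)o2)cc1` is the next member. Relative to compound 3 the change is (4-methoxyphenyl)amino in place of 2-fluorobenzyl on an aromatic carbon. Within the data shown here, no measured pair in the set covers a change of this kind at that carbon of the five-membered ring; the one step that bears on it at all, a 1.6-fold higher number from compound 1 to compound 2 (0.20 log units; within the scatter), concerns the same methoxy on the outer benzene ring and was within the scatter. With the linking group altered as well, the precedent is thin, and nothing in the series argues for a shift beyond the scatter in either direction.

Compound 4 is therefore expected near compound 3, at 700 nM with a range of 250 nM to 2000 nM, a step of a 1.1-fold higher number from compound 3 to compound 4 (0.05 log units; within the scatter).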

Compound 4, inhibition constant: 79.4 nM
Compound 4: the middle estimate sits 8.8-fold (0.95 log units) above what was measured; measured number below the stated range.
By their numbers in this assay, from the lowest: compound 4; then compounds 1, 2 and 3 (each within the scatter of the next).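

In this assay, within the data shown here, the replacement of 2-fluorobenzyl by (4-methoxyphenyl)amino on the aromatic carbon of the five-membered ring is the first change in the set to lie beyond the scatter (a 7.9-fold lower number from compound 3 to compound 4 (0.90 log units; beyond the scatter)). Among these compounds, this position therefore responds to a change in what joins the outer benzene ring to the core, whereas the one earlier step, at the outer ring alone, stayed within the scatter. The replacement alters the link and the outer ring substituents together, bringing in a hydrogen-bond donor and acceptors where the leaving group has none, and no measurement here accounts for the size of the step.

Still open, from the compounds shown here alone, is whether the gain follows the amine link or the methoxy: a phenylamino group without methoxy at this carbon, and a 4-methoxybenzyl group on the chloro-methylphenyl series, would separate the two. Also open, going by these compounds, is whether the amine hydrogen matters, which an N-methylamino link or an ether oxygen in its place would test.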